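The source may hold more compounds than are shown below. What is called first, only, known or untested is meant among the compounds shown, and "the series" means these compounds.

Measured in a functional assay on cells (Cancer cell lines, Homo sapiens) for inhibition; on this read-out lower numbers stand for stronger inhibition of growth and higher numbers for weaker inhibition of growth:
- Compound 1 `Cc1cc(-c2nc3sc(C)cn3c2/C=N/NC(=N)N)c(C)s1`: 8320 nM
- Compound 2 `N=C(N)N/N=C/c1c(-c2ccsc2)nc2sccn12`: 15100 nM
- Compound 3 `N=C(N)N/N=C/c1c(-c2cccs2)nc2sccn12`: 12000 nM

Compound 3 sits among these three numbers, and both compound 2 and compound 1 lie within the usual scatter of it. Nothing here separates the three compounds in this assay.

Compound 4 `Cc1cc(-c2nc3sccn3c2/C=N/NC(=N)N)c(C)s1` has not yet been measured. The change to it is 2,5-dimethylthiophen-3-yl in place of thiophen-2-yl on an aromatic carbon of the five-membered aromatic ring with 2 nitrogen.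

Two pieces of evidence bear on this change. Among the compounds with values here, the only measured step at this place is a 1.3-fold lower number from compound 2 to compound 3 (0.10 log units; within the scatter), a swap between two thiophene groups that changed little. Compound 1, at 8320 nM, already carries 2,5-dimethylthiophen-3-yl, although it also has an extra methyl on the shared core, so it is not a clean comparison. Its value does, however, stay within the scatter of the values for the plain thiophene compounds.

No step beyond the scatter is therefore expected, and the estimated step is a 1.2-fold lower number from compound 3 to compound 4 (0.08 log units; within the scatter). Compound 4 is expected at about 10000 nM, with an estimated range of 5000 nM to 20000 nM.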

Compound 4, concentration for 50% growth inhibition: 15500 nM
Estimate against measurement, compound 4: 1.6-fold (0.19 log units) below, within the range that was stated.
By their numbers in this assay, from the lowest: compounds 1, 3, 2 and 4 (each within the scatter of the next).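

In this assay, putting 2,5-dimethylthiophen-3-yl at this position gives a 1.3-fold higher number from compound 3 to compound 4 (0.11 log units; within the scatter) when it replaces thiophen-2-yl and a 1.0-fold higher number from compound 2 to compound 4 (0.01 log units; within the scatter) when it replaces thiophen-3-yl, so this position accepts the two extra methyl groups without a readable difference from either plain thiophene. Compound 4 also gives the first clean view of the methyl on the shared core, since hydrogen in place of that methyl gives a 1.9-fold higher number from compound 1 to compound 4 (0.27 log units; within the scatter), and this difference also stays within the scatter. No measurement shown here offers an explanation for these small steps.

Every group shown at this position is a thiophene, so it remains open how a phenyl ring, an amine or a carboxylic acid would behave there. All four compounds lie within the scatter of their neighbours in the ranking, so the set does not show which change at this position, if any, would move the number beyond the scatter.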